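Exchanging one pyridyl for another on a shared core

The compounds below may be only part of what the source reports. "The series", "measured", "known", "first", "only" and "open" are said of these compounds alone.

Of the compounds shown here, three that share one core have been measured. Compound 1 `CC(C)c1cc(-c2ccccc2)c(-c2ccc(F)cc2)n1/C=C/[C@@H](O)C[C@@H](O)CC(=O)O` carries a phenyl on that core; in an assay on isolated protein for inhibition of 3-hydroxy-3-methylglutaryl-coenzyme A reductase (Homo sapiens) (a lower number here means a stronger inhibitor, a higher number a weaker inhibitor), compound 1 gives 8.7 nM. Compound 2 `CC(C)c1cc(-c2cccc(Br)c2)c(-c2ccc(F)cc2)n1/C=C/[C@@H](O)C[C@@H](O)CC(=O)O` carries a 3-bromophenyl in its place, and in this assay compound 2 gives 9.3 nM. Compound 3 `CC(C)c1cc(-c2ccncc2)c(-c2ccc(F)cc2)n1/C=C/[C@@H](O)C[C@@H](O)CC(=O)O` carries a pyridin-4-yl, and in this assay compound 3 gives 8.3 nM. Compound 3 thus sits alongside the other two rather than apart from them: the change a 1.0-fold lower number from compound 1 to compound 3 (0.02 log units; within the scatter) and the change a 1.1-fold lower number from compound 2 to compound 3 (0.05 log units; within the scatter) are both within the scatter, as is a 1.1-fold higher number from compound 1 to compound 2 (0.03 log units; within the scatter). Compound 4 `CC(C)c1cc(-c2ccccn2)c(-c2ccc(F)cc2)n1/C=C/[C@@H](O)C[C@@H](O)CC(=O)O` differs from compound 3 only in pyridin-2-yl in place of pyridin-4-yl on an aromatic carbon. Every measured exchange at this position, whether phenyl, 3-bromophenyl or pyridin-4-yl, has left the number within the scatter, so exchanging one pyridyl for the other is expected to do the same: the expected step is a 1.1-fold higher number from compound 3 to compound 4 (0.06 log units; within the scatter), with no direction beyond the scatter. Compound 4 is therefore estimated at 9.5 nM, with a range from 4 nM to 25 nM.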

Compound 4, half-maximal inhibitory concentration: 8.7 nM
Compound 4: the middle estimate sits 1.1-fold (0.04 log units) above what was measured; low and high end bracket the measured number.
By their numbers in this assay, from the lowest: compounds 3, 1, 4 and 2 (each within the scatter of the next).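

Moving the ring nitrogen, with the atoms of the group otherwise unchanged, has no measurable consequence in this assay: there is a 1.0-fold higher number from compound 3 to compound 4 (0.02 log units; within the scatter). Within the data shown here, the earlier compounds tested pyridin-4-yl only, so this is the first sign that the place of the nitrogen within the ring does not register here, and pyridin-2-yl also stays level with the other two groups, with no change at the digits printed from compound 1 to compound 4 (within the scatter) and a 1.1-fold lower number from compound 2 to compound 4 (0.03 log units; within the scatter). No measurement offered here explains why this position tolerates these exchanges.

Among these compounds, all four groups at this position are six-membered aromatic rings, so the flat picture covers only that kind of group. From the compounds shown here alone, whether pyridin-3-yl, or a group of another kind such as an amine, a carboxylic acid or a longer chain, would also stay within the scatter remains open.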